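Adding a Third Methyl to a Weak Exchange-Factor Inhibitor

The source may report more compounds than this note shows. Statements on the series, on what has been measured and on what is new or still open speak of the compounds shown alone.

Measured compounds:
Compound 1 `Cc1ccc(CSc2nc(C3CCCCC3)c(C#N)c(=O)[nH]2)cc1`: 38700 nM
Compound 2 `Cc1ccc(CSc2nc(C3CCCCC3)c(C#N)c(=O)[nH]2)c(C)c1`: 15700 nM

Both compounds share one core and differ only in the methyl groups on the aromatic ring. In an assay on isolated protein for inhibition of Rap guanine nucleotide exchange factor 4 (Homo sapiens), read by fluorescence and cAMP accumulation (a higher number here means a weaker inhibitor, a lower number a stronger inhibitor), compound 1 gives 38700 nM, and compound 2 gives 15700 nM. Compound 2 therefore stands at the lowest of the two numbers, and the gap to compound 1 is beyond the scatter: a 2.5-fold lower number from compound 1 to compound 2 (0.39 log units; beyond the scatter).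

Compound 3 `Cc1cc(C)c(CSc2nc(C3CCCCC3)c(C#N)c(=O)[nH]2)c(C)c1` has not yet been measured. It differs from compound 2 in one place: methyl in place of hydrogen on an aromatic carbon. The new methyl sits on an aromatic carbon of a six-membered aromatic ring of carbon only, ortho to a large group and meta to two methyl groups.

For the measured compounds named here, the only step that bears on this change is the one from compound 1 to compound 2, where a methyl entering the same ring lowered the number modestly. A second such methyl is expected to give a step of similar or smaller size in the same direction, a 1.7-fold lower number from compound 2 to compound 3 (0.24 log units; within the scatter), so compound 3 is estimated at 9000 nM, within a range from 4000 nM to 20000 nM.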

Compound 3, half-maximal inhibitory concentration: 11600 nM
Beside the measured number, compound 3's estimate is 1.3-fold (0.11 log units) below it, and the stated range covers the measured number.
By their numbers in this assay, from the lowest: compounds 3 and 2 (each within the scatter of the next); then compound 1.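

In this assay, the methyl that enters ortho to a large group and meta to two methyl groups gives a 1.4-fold lower number from compound 2 to compound 3 (0.13 log units; within the scatter), so compound 3 cannot be told apart from compound 2 in this measurement. The earlier methyl change gave a 2.5-fold lower number from compound 1 to compound 2 (0.39 log units; beyond the scatter), so that step alone could not show that a methyl at this further ring position would produce no step beyond the scatter. The data offer no measured explanation for this result.

Still open, going by these compounds, is whether a different group at this same position, such as a hydroxyl, an amine, a carboxylic acid or a longer chain like ethyl, would produce a step beyond the scatter in either direction. Also open is whether the methyl would behave the same way on a compound with a different ring substitution, since the compounds shown test this position on only one background, compound 2.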